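A few compounds are considered here, and "the series" means these few. Any claim that something is new, unique, unknown or untested is made for them only; others in the source may bear on it.

Three compounds of one series have been run in a functional assay on the whole organism (Abdomen, strain Swiss albino) with Mus musculus as the target, with stated times of 10 min and 5 min, at a dose of 15 mg/kg by the oral route; on this read-out lower numbers stand for a weaker effect and higher numbers for a stronger effect at the one dose given. Compound 1 `CCOC(=O)c1onc(-c2cn(-c3ccccc3)nc2-c2ccc(Br)cc2)c1C(=O)OCC` gives 12.9%. Compound 2 `Brc1ccc(-c2nn(-c3ccccc3)cc2-c2cc(-c3ccccc3)on2)cc1` gives 14.5%. Compound 3 `COc1ccc(-c2nn(-c3ccccc3)cc2-c2cc(-c3ccccc3)on2)cc1` gives 11.8%. Compound 3 carries the lowest of the three numbers, its nearest neighbour being compound 1 and its furthest compound 2, yet both gaps fall within the scatter, so the three read as one level. For the measured compounds named here, the only step among measured compounds that changes a single place is a number 2.7 percentage points lower from compound 2 to compound 3 (within the scatter), also within the scatter.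

Compound 4 `Clc1ccc(-c2nn(-c3ccccc3)cc2-c2cc(-c3ccccc3)on2)cc1` has not been measured. From compound 3 the change is chloro in place of methoxy on an aromatic carbon. Going by the values given here, the step that bears on it is the one from compound 2 to compound 3, in which bromo gave way to methoxy at this position without moving the number beyond the scatter; a halogen at this position in compound 2 thus sat at the same level as methoxy. The expected step, a number 1.7 percentage points higher from compound 3 to compound 4 (within the scatter), is therefore none beyond the scatter in this assay. Compound 4 is expected to give 13.5%, with a range from 6% to 22%.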

Compound 4, a percentage reported as activity, at one dose (the size of the read-out at that dose, not a potency): 1.58%
Estimate against measurement, compound 4: 11.9 percentage points above; measured number outside the range, below it.
By their numbers in this assay, from the lowest: compound 4; then compounds 3, 1 and 2 (each within the scatter of the next).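

In this assay, this position proves sensitive to the group it carries, with a number 10.2 percentage points lower from compound 3 to compound 4 (beyond the scatter) and a number 12.9 percentage points lower from compound 2 to compound 4 (beyond the scatter). The earlier step, a number 2.7 percentage points lower from compound 2 to compound 3 (within the scatter), suggested that the group here made little difference, but chloro now stands apart from both bromo and methoxy, so the two halogens do not read as one level on this shared core. No measurement at hand accounts for the separation of chloro from the other two groups.

The compounds shown leave open whether fluoro, methyl or an amine on this aromatic carbon would sit with chloro or with bromo and methoxy. They also leave open whether chloro in place of bromo gives a similar step on the core of compound 1, which carries two ethyl ester groups.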